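A few compounds are considered here, and "the series" means these few. Any claim that something is new, unique, unknown or untested is made for them only; others in the source may bear on it.

Measured in an ADME assay on BJ cells (Homo sapiens) for cytotoxicity, with a stated time of 72 h; a higher number here means that more compound is needed for the effect, a lower number that less compound is needed:

- compound 1 `Cc1cc(NC(=O)Nc2ccc(C(=O)O)cc2)c2ccccc2n1`: > 25000 nM (a limit of the assay, not a number)
- compound 2 `Cc1cc(NC(=O)Nc2cc(F)ccc2F)c2ccccc2n1`: 7000 nM
- compound 3 `Cc1cc(NC(=O)Nc2ccccc2C(F)(F)F)c2ccccc2n1`: > 25000 nM (a limit of the assay, not a number)

Compound 1 stands at the limit of > 25000 nM in this assay, at which 2 of the 3 values shown sit, in this assay; its value is a limit only, so no number is known for it. Compound 3 sits at the same limit in this assay. Compound 2 is the only one of the three with a number in this assay, and it lies below that limit.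

Compound 4 `Cc1cc(NC(=O)Nc2ccc(O)cc2)c2ccccc2n1` has not yet been measured in this assay. It differs from compound 1 as follows: hydroxy in place of carboxy on an aromatic carbon. No step between two measured compounds is known in this assay, so the size of this change cannot be read from the data shown; the one number in the set, that of compound 2, lies within an order of the limit, and nothing in the set argues for a large move in either direction.

For compound 4 the expected step in this assay, an at least 1.2-fold lower number from compound 1 to compound 4 (0.09 log units; that floor lies within the scatter), is small, toward a lower number if any, and possibly not beyond the scatter. Compound 4 is estimated at 20000 nM in this assay, with a range from 7000 nM to 40000 nM, and a fair chance that only a limit is reported again.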

Compound 4, half-maximal effective concentration: > 25000 nM
Compound 4 ended at the assay's limit; the forecaster's own chance of this, stated with the estimate: 55%; middle value at least 1.2-fold (0.09 log units) from the limit.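

Compound 1 and compound 4 both give only a limit in this assay, so no step can be read for hydroxy in place of carboxy, and the result adds one more value to the limit: the limit of > 25000 nM in this assay, at which 3 of the 4 values shown sit.

The compounds shown leave open the size and the direction of this change in this assay.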